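Replacing the tolyl amide by a plain octyl chain

The compounds below may be only part of what the source reports. "The series", "measured", "known", "first", "only" and "open" are said of these compounds alone.

Measured so far:
Compound 1 `CCOC(=O)C1=Cc2ccccc2OC1(OCc1cn(CC(=O)NC2CCCCC2)nn1)C(F)(F)F` — 10200 nM
Compound 2 `CCOC(=O)C1=Cc2ccccc2OC1(OCc1cn(CC(=O)Nc2ccc(C)cc2)nn1)C(F)(F)F` — > 150000 nM

Compound 1 `CCOC(=O)C1=Cc2ccccc2OC1(OCc1cn(CC(=O)NC2CCCCC2)nn1)C(F)(F)F` carries a cyclohexyl amide and, in a functional assay on DU-145 cells (Homo sapiens) for inhibition, read by MTT assay, with a stated time of 24 h (a lower number here means a stronger inhibitor, a higher number a weaker inhibitor), compound 1 gives 10200 nM. Compound 2 `CCOC(=O)C1=Cc2ccccc2OC1(OCc1cn(CC(=O)Nc2ccc(C)cc2)nn1)C(F)(F)F` differs only in the amide substituent. For compound 2 the result in this assay is a limit, not a number: > 150000 nM. The single measured step, an at least 14-fold higher number from compound 1 to compound 2 (1.16 log units; beyond the scatter), runs from a number to a limit, as shown by the limit of > 150000 nM in this assay, at which 1 of the 2 values shown sits.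

Compound 3 `CCCCCCCCn1cc(COC2(C(F)(F)F)Oc3ccccc3C=C2C(=O)OCC)nn1` is the next compound. The change from compound 2 is heptyl in place of (4-methylphenyl)carbamoyl on a saturated chain carbon bound to an aromatic nitrogen. Here the whole amide group disappears and only a hydrocarbon chain remains, so the one measured step speaks to it only loosely; it shows that this assay is sensitive to what sits on the triazole. Compound 2 stands at the weak end of the two values. The step of an at least 5.0-fold lower number from compound 2 to compound 3 (0.69 log units; beyond the scatter) is an expectation with wide uncertainty. For compound 3 in this assay a value of 30000 nM is estimated, in the range 4000 nM to 150000 nM.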

Compound 3, half-maximal inhibitory concentration: > 150000 nM
Compound 3: a limit, no number; the forecaster's own chance of this, stated with the estimate: 35%; at least 5.0-fold (0.69 log units) between middle value and limit.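

In this assay compound 3 gives only a limit, > 150000 nM, so the step from compound 2, where both values are limits, cannot be read. The step that can be read is an at least 14-fold higher number from compound 1 to compound 3 (1.16 log units; beyond the scatter), so the octyl chain gives up as much of the measured effect of compound 1 as the 4-methylphenyl amide does. Compound 2 keeps the amide and compound 3 has none, yet both end at the same limit, so among these compounds only the cyclohexyl amide gives a real number: the limit of > 150000 nM in this assay, at which 2 of the 3 values shown sit.

The compounds shown leave open whether the number for compound 1 depends on the cyclohexyl ring alone or on that ring together with the amide. Also open, going by these compounds, is how a cyclopentyl amide, a benzyl amide or a free carboxylic acid would read at this place.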